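A few compounds are considered here, and "the series" means these few. Any claim that something is new, unique, unknown or untested is made for them only; others in the source may bear on it.

Working notes on the series in a functional assay on MDA-MB-468 cells (Homo sapiens) for antiproliferative activity, read by sulforhodamine B assay, with a stated time of 72 h; a higher number here means a weaker inhibitor, a lower number a stronger inhibitor. Compound 1 `COc1ccc2nc(Cl)c(/C=C\c3ccc(C(F)(F)F)cc3)cc2c1` gives 22700 nM, and compound 2 `FC(F)(F)c1cccc(/C=C/c2cc3ccccc3nc2Cl)c1` gives 24000 nM. Compound 3 `COc1ccc2nc(Cl)c(/C=C\c3ccc(C(F)(F)F)cc3C(F)(F)F)cc2c1` reads > 50000 nM, which is a limit of the assay and not a number. Its standing on the numbers shown is therefore only (the limit of > 50000 nM in this assay, at which 1 of the 3 values shown sits), and no exact starting value exists for the next step.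

Compound 4 `COc1ccc2nc(Cl)c(/C=C\c3ccccc3C(F)(F)F)cc2c1` comes from compound 3 by hydrogen in place of trifluoromethyl on an aromatic carbon. The group that leaves sits para to a large group and meta to a trifluoromethyl group, and that second trifluoromethyl stays.

Within the data shown here, the one measured step that bears on this is an at least 2.2-fold higher number from compound 1 to compound 3 (0.34 log units; beyond the scatter). It is also an exchange of hydrogen and trifluoromethyl on an aromatic carbon, but it runs in the opposite sense and at the other place on that ring. Compound 4 keeps a single trifluoromethyl, as does compound 1 at 22700 nM, so a return towards that range is expected, with a step of similar modest size to a lower number in this assay. Another reading at the limit remains possible. The expected move is an at least 1.7-fold lower number from compound 3 to compound 4 (0.25 log units; that floor lies within the scatter). For compound 4 the estimated value is 28000 nM, with an expected range of 11000 nM to 50000 nM.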

Compound 4, half-maximal inhibitory concentration: 4980 nM
The estimate for compound 4 lay 5.6-fold (0.75 log units) above the measured number; the whole stated range lies above it.
By their numbers in this assay, from the lowest: compound 4; then compounds 1 and 2 (each within the scatter of the next). At a limit, above all of these: compound 3.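

In this assay, hydrogen in place of trifluoromethyl on the aromatic carbon para to a large group gives an at least 10-fold lower number from compound 3 to compound 4 (1.00 log units; beyond the scatter), which shows that this position responds clearly to this change while the other trifluoromethyl stays. The earlier step, an at least 2.2-fold higher number from compound 1 to compound 3 (0.34 log units; beyond the scatter), concerned the other place on that ring, and since both steps run to or from compound 3, neither has an exact size and the two cannot be set against each other. The value of compound 3 is a limit of the assay and not a number, so the new step is only a floor because of that limit: the limit of > 50000 nM in this assay, at which 1 of the 4 values shown sits.

Open is how this aromatic carbon would read with a methoxy group, an amine or a carboxylic acid, as only hydrogen and trifluoromethyl appear there in the compounds shown. Also open, from the compounds shown here alone, is how compound 4 would read with a nitrile or a longer chain in place of its remaining trifluoromethyl.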